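Swapping a Phenol for a Piperidine on a Shared Core

The source may hold more compounds than are shown below. What is called first, only, known or untested is meant among the compounds shown, and "the series" means these compounds.

Compound 1 `Oc1ccc(CNc2cc(C(F)(F)F)cc3[nH]ncc23)cc1`: 36700 nM
Compound 2 `O=C(O)CNc1cccc(CNc2cc(C(F)(F)F)cc3[nH]ncc23)c1`: > 100000 nM
Compound 3 `Oc1ccc(CNc2cc(C(F)(F)F)cc3[nH]ncc23)c(Cl)c1`: 6020 nM

In an assay for inhibition of Indoleamine 2,3-dioxygenase 1 (Homo sapiens), with stated times of 10 min and 60 min (a higher number here means a weaker inhibitor, a lower number a stronger inhibitor), compound 1 gives 36700 nM, the higher of the two numbers recorded. Among the compounds with values here, compound 3 gives 6020 nM, and the one single-point step seen so far is a 6.1-fold lower number from compound 1 to compound 3 (0.79 log units; beyond the scatter). For compound 2 the assay reports only a limit, > 100000 nM, not a number; this is the limit of > 100000 nM in this assay, at which 1 of the 3 values shown sits.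

The new compound 4 `FC(F)(F)c1cc(NC[C@@H]2CCCCN2)c2cn[nH]c2c1` differs from compound 1 by piperidin-2-yl in place of 4-hydroxyphenyl on a saturated chain carbon bound to a nitrogen on an aromatic ring. Within the data shown here, no measured step touches this part of the molecule: the only step recorded concerns a chloro added elsewhere, and compound 2 offers just a limit. The change is therefore unanchored, and no direction beyond the scatter can be read from the data.

Compound 4 is estimated to give 40000 nM, within a wide range from 8000 nM to 200000 nM, which means an expected step of a 1.1-fold higher number from compound 1 to compound 4 (0.04 log units; within the scatter).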

Compound 4, half-maximal inhibitory concentration: 18700 nM
Beside the measured number, compound 4's estimate is 2.1-fold (0.33 log units) above it; low and high end bracket the measured number.
By their numbers in this assay, from the lowest: compound 3; then compounds 4 and 1 (each within the scatter of the next). At a limit, above all of these: compound 2.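

In this assay, piperidin-2-yl in place of 4-hydroxyphenyl gives a 2.0-fold lower number from compound 1 to compound 4 (0.29 log units; within the scatter), so this is no change beyond the usual scatter. Within the data shown here, this is the first measured change at this position, on the saturated chain carbon bound to a nitrogen on an aromatic ring, and it shows that a six-membered aromatic ring of carbon only can give way to a non-aromatic ring with one hetero atom while the number stays within the scatter of compound 1. No recorded measurement explains why the two groups give such similar numbers.

Going by these compounds, it remains open whether the opposite stereocentre, a smaller pyrrolidine ring or a morpholine ring would give a similar number at this position. The compounds shown also leave open whether adding a chloro to the shared core of compound 4 would lower its number as it does from compound 1 to compound 3.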